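Working notes: from compound 2 to compound 3

The source may report more compounds than this note shows. Statements on the series, on what has been measured and on what is new or still open speak of the compounds shown alone.

Of the compounds shown here, two with the shared core have been measured so far. In a functional assay on BaF3 cells (Mus musculus) for inhibition, read by CCK-8 assay, with a stated time of 72 h (a higher number here means a weaker inhibitor of growth, a lower number a stronger inhibitor of growth), compound 1 (`Cc1ccc(NC(=O)Nc2ccc(Oc3cc(/N=C/N(C)C)ncn3)cc2)cc1C(F)(F)F`) gives a value of 6610 nM and compound 2 (`Cc1ccc(NC(=O)Nc2ccc(Oc3cc(N4CCNC[C@@H]4C)ncn3)cc2)cc1C(F)(F)F`) gives 8120 nM as its value. Compound 2 therefore stands level with compound 1, the two numbers lying within the scatter of each other.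

Compound 3 (`Cc1ccc(NC(=O)Nc2ccc(Oc3cc(NCCO)ncn3)cc2)cc1C(F)(F)F`) differs from compound 2 by one change ((2-hydroxyethyl)amino in place of 2-methylpiperazin-1-yl on an aromatic carbon): (2-hydroxyethyl)amino in place of 2-methylpiperazin-1-yl on an aromatic carbon. Among the measured compounds shown here, the only measured step that bears on this change is the exchange at that same carbon between compound 1 and compound 2 (a 1.2-fold higher number from compound 1 to compound 2 (0.09 log units; within the scatter)), which stays within the scatter. For the measured compounds named here, that single step swapped a group with no ring for a ring group, as the new change does in reverse, but no measured compound carries the (2-hydroxyethyl)amino group, so the support is thin. In this assay the expected outcome is no step beyond the scatter, estimated as a 1.2-fold lower number from compound 2 to compound 3 (0.06 log units; within the scatter) without a firm direction. For compound 3 the estimated value is about 7000 nM (expected range 2800 nM to 16000 nM).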

Compound 3, concentration for 50% growth inhibition: > 10000 nM
Compound 3: a limit, no number (the forecaster's own chance of this, stated with the estimate: 15%); at least 1.4-fold (0.15 log units) between middle value and limit.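

In this assay compound 3 gives > 10000 nM, which is a limit of the assay and not a number. Read against the two earlier compounds, this result gives an at least 1.2-fold higher number from compound 2 to compound 3 (0.09 log units; that floor lies within the scatter) and an at least 1.5-fold higher number from compound 1 to compound 3 (0.17 log units; that floor lies within the scatter), so neither floor shows that (2-hydroxyethyl)amino in place of 2-methylpiperazin-1-yl on this aromatic carbon moves the number beyond the scatter, though the true size of each step may be larger than its floor. This position has now carried three groups, two without a ring and one with a ring, no step among them is printed as beyond the scatter, and the series has reached the ceiling of the read-out for the first time: the limit of > 10000 nM in this assay, at which 1 of the 3 values shown sits.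

On these data alone, whether a smaller unsubstituted amine, a morpholine ring, a carboxylic acid or a longer chain on this carbon would give a clearly lower number remains open. Also open, as far as these compounds go, is whether the hydroxyl of the (2-hydroxyethyl)amino group matters, which a plain ethylamino group at the same carbon would test, and how far compound 3 truly lies from compound 1 and compound 2.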